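This account rests on a few compounds, and the source may have more. Where it says the series, first, only, none or still open, it means among the compounds named here.

Of the compounds shown here, two have been measured so far. Compound 1 `CC(C)S(=O)(=O)Nc1ccc(CNC(=O)c2ccc(C(C)(C)C)cc2)c(Cl)c1` gives 420 nM in an assay on HeLa cells for agonist activity at Bile acid receptor (Homo sapiens), read by a luciferase reporter, with a stated time of 24 h; on this read-out higher numbers stand for an effect only at larger amounts of compound and lower numbers for an effect already at smaller amounts. Compound 2 `CS(=O)(=O)Nc1ccc(CNC(=O)c2ccc(N3CCC3)cc2)c(Cl)c1` gives 13000 nM in this assay, the highest of the two numbers; its nearest neighbour is compound 1, and the gap between the two lies well beyond the usual scatter. Compound 1 and compound 2 differ in more than one place, so their two values alone cannot be traced to any single change. Compound 3 `CC(C)Oc1ccc(C(=O)NCc2ccc(NS(C)(=O)=O)cc2Cl)cc1` is still to be measured in this assay. It differs from compound 2 in one place only: isopropoxy in place of azetidin-1-yl on an aromatic carbon. Within the data shown here, no measured pair isolates this change, so the expectation rests on a cautious reading of the numbers. A moderate step toward a lower number is expected, a 3.3-fold lower number from compound 2 to compound 3 (0.51 log units; beyond the scatter). For compound 3 the estimated value is 4000 nM, with a range from 1000 nM to 15000 nM.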

Compound 3, half-maximal effective concentration: 400 nM
The estimate for compound 3 lay 10-fold (1.00 log units) above the measured number; the measured number lies below the stated range.
By their numbers in this assay, from the lowest: compounds 3 and 1 (each within the scatter of the next); then compound 2.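

Exchanging azetidin-1-yl for isopropoxy on an aromatic carbon, para to a large group, gives a 33-fold lower number from compound 2 to compound 3 (1.51 log units; beyond the scatter) in this assay. Among these compounds, this is the first pair in which only one group differs, and it shows that this position alone can move the read-out by a large amount, even though both groups have 4 heavy atoms, 0 hydrogen-bond donors, 1 hydrogen-bond acceptor and no net charge. No measurement here explains why the read-out moves.

The compounds shown do not tell whether the step follows the oxygen in place of nitrogen or the open chain in place of the four-membered ring. An isopropylamino group would pair the open chain with nitrogen, and a cyclobutoxy group would pair oxygen with a ring, so both would bear on that question.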